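A Methyl on an Aromatic Oxygen, Tested in Two Cores

A few compounds are considered here, and "the series" means these few. Any claim that something is new, unique, unknown or untested is made for them only; others in the source may bear on it.

The measured compounds:
compound 1, `O=C(Nc1cccc(-n2cc(-c3ccncc3)c(-c3cc(O)cc(Cl)c3)n2)c1)Nc1ccc(Cl)c(C(F)(F)F)c1`: 63.1%
compound 2, `COc1cc(Cl)cc(-c2nn(-c3cccc(NC(=O)Nc4ccc(Cl)c(C(F)(F)F)c4)c3)cc2-c2ccncc2)c1`: 12%
compound 3, `O=C(Nc1cccc(-n2cc(-c3ccncc3)c(-c3cc(O)cc(Cl)c3)n2)c1)c1cc(C(F)(F)F)cc(C(F)(F)F)c1`: 68.9%

In a functional assay on SK-OV-3 cells (Homo sapiens) for inhibition, read by sulforhodamine B assay, with a stated time of 48 h, tested at 10 uM (a lower number here means a stronger effect, a higher number a weaker effect of the compound at the concentration tested), compound 1 gives 63.1%. Compound 2 differs from it in one place, (methyl in place of hydrogen on an oxygen on an aromatic ring), and the step of a number 51.1 percentage points lower from compound 1 to compound 2 (beyond the scatter) is a large one. In this assay compound 3 gives 68.9%, which stands within the scatter of compound 1; the difference between the two cores of compound 1 and compound 3 is not broken down here. Compound 4, `COc1cc(Cl)cc(-c2nn(-c3cccc(NC(=O)c4cc(C(F)(F)F)cc(C(F)(F)F)c4)c3)cc2-c2ccncc2)c1`, is not yet measured. It differs from compound 3 by methyl in place of hydrogen on an oxygen on an aromatic ring, the same change that separates compound 1 from compound 2, made at the same place on the same 3-chloro-5-hydroxyphenyl group. Among the compounds with values here, since that change has been seen only once, the expectation for compound 4 rests on the single step of a number 51.1 percentage points lower from compound 1 to compound 2 (beyond the scatter) of compound 1. A step of about a number 48.9 percentage points lower from compound 3 to compound 4 (beyond the scatter) is expected from compound 3 to compound 4. The core of compound 3 is not the core of compound 1; this leaves the expectation somewhat less sure. Compound 4 is thus estimated at 20% in this assay, most likely between 5% and 50%.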

Compound 4, a percentage reported as activity, at one concentration (the size of the read-out at that concentration, not a potency): 83.4%
Estimate against measurement, compound 4: 63.4 percentage points below; the whole stated range lies below it.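

In this assay, replacing hydroxy with methoxy on the 3-chloro-5-hydroxyphenyl group gives a number 14.5 percentage points higher from compound 3 to compound 4 (beyond the scatter), so in this pair the number rises where it fell for the same change in the core of compound 1. Within the data shown here, with only two pairs, this does not show which part of the two cores decides the direction of the step, nor does it give a rule for any further core. What it does show is that the change cannot be carried from one core to the other as a fixed amount, since the two steps do not agree in direction or in size: the same change on two cores in this assay, a number 51.1 percentage points lower (beyond the scatter) from compound 1 to compound 2 and a number 14.5 percentage points higher (beyond the scatter) from compound 3 to compound 4, 65.6 percentage points apart, beyond the scatter of two such steps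

The compounds shown leave open how a longer chain on that oxygen, such as an ethyl group, would behave on either core. They also leave open whether an amine in place of the hydroxy would follow the methoxy step on the core of compound 1 or that on the core of compound 3.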